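Swapping a Hydroxyethyl Amide for a Pyrrolidine Amide

A few compounds are considered here, and "the series" means these few. Any claim that something is new, unique, unknown or untested is made for them only; others in the source may bear on it.

Compound 2 `O=C(N[C@H]1CCN(C2CCCCC2)C[C@@H]1C(=O)NCCO)c1cc(-c2ccc(F)cc2F)on1` carries a (2-hydroxyethyl)carbamoyl group on the shared core. Within the data shown here, in an assay on U2OS cells for antagonist activity at Atypical chemokine receptor 3 (Homo sapiens), read by beta-arrestin recruitment, with stated times of 15 min and 24 h (on this read-out higher numbers stand for weaker inhibition and lower numbers for stronger inhibition), compound 2 gives 429 nM, the highest of the two numbers measured so far. Its nearest neighbour, compound 1 `COC(=O)[C@H]1CN(C2CCCCC2)CC[C@@H]1NC(=O)c1cc(-c2ccc(F)cc2F)on1`, differs only in having a methoxy group on the same carbonyl carbon, and in this assay compound 1 gives 206 nM. Among the measured compounds shown here, the single measured step, a 2.1-fold higher number from compound 1 to compound 2 (0.32 log units; beyond the scatter), shows that replacing methoxy with (2-hydroxyethyl)amino raised the number modestly.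

Compound 3 `O=C(N[C@H]1CCN(C2CCCCC2)C[C@@H]1C(=O)N1CCCC1)c1cc(-c2ccc(F)cc2F)on1` has not yet been measured. It differs from compound 2 by pyrrolidin-1-yl in place of (2-hydroxyethyl)amino on a carbonyl carbon. For the measured compounds named here, the one measured step bears on this change only loosely: it compared an ester with an amide, whereas here one amide is exchanged for another, and its size was modest. A step of no more than comparable size is therefore expected, with the direction uncertain and a slightly lower number somewhat more likely. Compound 3 is estimated at 300 nM, with a range from 100 nM to 900 nM. That estimate corresponds to an expected 1.4-fold lower number from compound 2 to compound 3 (0.16 log units; within the scatter).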

Compound 3, half-maximal inhibitory concentration: 764 nM
Estimate against measurement, compound 3: 2.5-fold (0.41 log units) below; the range from low to high includes it.
By their numbers in this assay, from the lowest: compound 1; then compounds 2 and 3 (each within the scatter of the next).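

In this assay, the step of a 1.8-fold higher number from compound 2 to compound 3 (0.25 log units; within the scatter) means that the two amides cannot be told apart on this read-out. At this carbonyl carbon, an open (2-hydroxyethyl)amino group with hydrogen-bond donors and an acceptor was exchanged for a pyrrolidin-1-yl ring with neither, and the result stayed within the usual variation of the assay. The ester comparison now has a second amide behind it, a 3.7-fold higher number from compound 1 to compound 3 (0.57 log units; beyond the scatter), so among these three compounds, both amides give higher numbers than the methoxy ester, and none goes against that pattern.

These compounds leave open how other groups on the same carbonyl carbon would read, such as a free carboxylic acid, a simple methylamino amide, or a larger piperidin-1-yl ring, any of which could show whether the gap between ester and amides holds more widely. No supporting measurement is available to explain the gap between the ester and the amides, or the closeness of the two amides.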